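The source may report more compounds than this note shows. Statements on the series, on what has been measured and on what is new or still open speak of the compounds shown alone.

Measured compounds in a functional assay on PC-3 cells (Homo sapiens) for antiproliferative activity, read by MTT assay, with a stated time of 48 h; a higher number here means a weaker inhibitor, a lower number a stronger inhibitor:
Compound 1 `COc1cc(-c2nnc(SCC(=O)c3ccc(C(F)(F)F)cc3)n2N)cc(OC)c1OC`: compound 1 gives > 100000 nM, which is a limit of the assay and not a number.
Compound 2 `COc1cc(-c2nnc(SCC(=O)c3ccc(F)c(F)c3)n2N)cc(OC)c1OC`: compound 2 gives > 100000 nM, again a limit.
Compound 3 `COc1cc(-c2nnc(SCC(=O)c3ccccc3F)n2N)cc(OC)c1OC`: compound 3 gives 43100 nM.

Among the measured compounds shown here, compound 3 therefore holds the only numerical value; the other two sit at the limit of > 100000 nM in this assay, at which 2 of the 3 values shown sit. Compound 4 `COc1cc(-c2nnc(SCC(=O)Nc3ccccc3)n2N)cc(OC)c1OC` differs from compound 3 by anilino in place of 2-fluorophenyl on a carbonyl carbon. The steps of an at least 2.3-fold lower number from compound 1 to compound 3 (0.36 log units; beyond the scatter) and an at least 2.3-fold lower number from compound 2 to compound 3 (0.36 log units; beyond the scatter) both concern fluorine-bearing phenyl groups on the carbonyl, so they bear only loosely on this change, and the step that the two limits leave unreadable from compound 1 to compound 2 gives no size at all. For the measured compounds named here, no measured step resembles the present change, so no direction is favoured and the step of a 1.0-fold higher number from compound 3 to compound 4 (0.02 log units; within the scatter) is expected to stay within the scatter. Compound 4 is estimated at 45000 nM, between 12000 nM and 150000 nM.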

Compound 4, half-maximal inhibitory concentration: 37900 nM
Compound 4: middle estimate off by 1.2-fold (0.07 log units), on the high side; the range from low to high includes it.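

Replacing 2-fluorophenyl with anilino on the carbonyl carbon gives a 1.1-fold lower number from compound 3 to compound 4 (0.06 log units; within the scatter), so in this assay this position accepts a group carrying a hydrogen-bond donor with no readable change. Anilino also compares with the other two groups at this position, giving an at least 2.6-fold lower number from compound 2 to compound 4 (0.42 log units; beyond the scatter) and an at least 2.6-fold lower number from compound 1 to compound 4 (0.42 log units; beyond the scatter), and these two sizes are only lower bounds: the limit of > 100000 nM in this assay, at which 2 of the 4 values shown sit.

On these data alone, whether the amide hydrogen itself matters stays open, and a methylated anilino group would address that. A benzylamino group, with a longer chain to the ring, is also not among the compounds shown.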